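Replacing the penta-1,3-dien-1-yl chain of compound 2

This account rests on a few compounds, and the source may have more. Where it says the series, first, only, none or still open, it means among the compounds named here.

- Compound 1 `C/C=C/C(=O)N(Cc1ccc(OC)c([N+](=O)[O-])c1)c1cc(OC)c(OC)c(OC)c1` gives 510 nM
- Compound 2 `C/C=C/C=C/C(=O)N(Cc1ccc(OC)c(O)c1)c1cc(OC)c(OC)c(OC)c1` gives 180 nM
- Compound 3 `C/C=C/C(=O)N(Cc1ccc(OC)c(Br)c1)c1cc(OC)c(OC)c(OC)c1` gives 10500 nM

In a functional assay on KYSE-450 cells (Homo sapiens) for inhibition, read by MTT assay, with a stated time of 48 h (on this read-out lower numbers stand for stronger inhibition and higher numbers for weaker inhibition), compound 2 gives 180 nM, the lowest of the three numbers, beyond the scatter from both others. Its nearest neighbour is compound 1 and its furthest is compound 3. Compound 4 `COc1ccc(CN(C(=O)CCCCCl)c2cc(OC)c(OC)c(OC)c2)cc1O`, not yet measured, carries 4-chlorobutyl in place of penta-1,3-dien-1-yl on a carbonyl carbon. All three measured compounds have double bonds in the chain at this place, and compound 4 has none there. Going by the values given here, no measured step changes this group, so the evidence is indirect. Among the compounds with values here, the only step, a 21-fold higher number from compound 1 to compound 3 (1.31 log units; beyond the scatter), concerns an aromatic carbon, but it shows that one replacement in this set can move the number far. Since compound 2 already sits lowest at 180 nM, a move to a higher number is expected, estimated as an 11-fold higher number from compound 2 to compound 4 (1.05 log units; beyond the scatter). For compound 4 the expected value is 2000 nM, within an estimated range from 400 nM to 12000 nM.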

Compound 4, half-maximal inhibitory concentration: 770 nM
For compound 4 the middle estimate is 2.6-fold (0.41 log units) above the measured one, within the range that was stated.
By their numbers in this assay, from the lowest: compound 2; then compounds 1 and 4 (each within the scatter of the next); then compound 3.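

Going by these compounds alone, the first measured change at this place on the carbonyl carbon, read in this assay, is a 4.3-fold higher number from compound 2 to compound 4 (0.63 log units; beyond the scatter) and is modest in size. It shows that the chain can lose both of its double bonds, with the heavy-atom count unchanged, and that the number rises only modestly, a far smaller shift than the one seen on the aromatic carbon. The swap also brings in a chlorine, so the step reflects the loss of the double bonds and the entry of the chlorine together, and nothing available explains the shift.

The compounds shown leave open how a plain pentyl chain without chlorine would compare with 4-chlorobutyl. They also leave open what a longer chain or a terminal amine would do at this place.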